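The source may report more compounds than this note shows. Statements on the series, on what has been measured and on what is new or still open speak of the compounds shown alone.

Going by the values given here, in an ADME assay on HepG2 2.2.15 cells (Homo sapiens) for cytotoxicity (on this read-out higher numbers stand for lower toxicity in this test and lower numbers for higher toxicity in this test), compound 1 `CC(=O)NCC(=O)OCCc1c(-c2ccccc2Cl)c2cc(Cl)ccc2[nH]c1=O` gives 110000 nM, while compound 2 `O=C(OCCc1c(-c2ccccc2Cl)c2cc(Cl)ccc2[nH]c1=O)C1CCCCC1` gives 38000 nM, the lower of the two numbers measured so far. Compound 3 `CC(=O)N1CCC(C(=O)OCCc2c(-c3ccccc3Cl)c3cc(Cl)ccc3[nH]c2=O)CC1` keeps the shared core of compound 2 and changes one group: 1-acetylpiperidin-4-yl in place of cyclohexyl on a carbonyl carbon. Among the compounds with values here, the one measured step that bears on this, a 2.9-fold lower number from compound 1 to compound 2 (0.46 log units; beyond the scatter), put cyclohexyl in place of acetamidomethyl on the same carbonyl carbon. The entering group, like acetamidomethyl, carries an acetyl on nitrogen, so a partial reversal of that modest step is expected, although a single step is thin support. The expected change is a 2.1-fold higher number from compound 2 to compound 3 (0.32 log units; beyond the scatter), toward a higher number and no larger than the measured step. For compound 3 the estimated half-maximal cytotoxic concentration in this assay is 80000 nM, with an expected range of 35000 nM to 180000 nM.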

Compound 3, half-maximal cytotoxic concentration: 82000 nM
Compound 3: the middle estimate sits 1.0-fold (0.01 log units) below what was measured; the range from low to high includes it.
By their numbers in this assay, from the lowest: compound 2; then compounds 3 and 1 (each within the scatter of the next).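

In this assay, 1-acetylpiperidin-4-yl in place of cyclohexyl on this carbonyl carbon gives a 2.2-fold higher number from compound 2 to compound 3 (0.33 log units; beyond the scatter), so the earlier drop seen with cyclohexyl is largely undone by a group that also holds a six-membered ring. Set against acetamidomethyl, the same group gives a 1.3-fold lower number from compound 1 to compound 3 (0.13 log units; within the scatter), so these two groups, each with an acetyl on nitrogen, cannot be told apart here, and compound 2, the one compound without that acetyl, stands apart from both. Nothing in the available data explains these shifts.

As far as these compounds go, what stays open is whether the acetyl or the ring nitrogen alone goes with the higher number, a question that a piperidin-4-yl carrying a free amine would address. A carboxylic acid on the cyclohexyl ring, or a longer chain in place of acetamidomethyl, would show how far this position tolerates other groups.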